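Swapping 3,5-dimethylphenyl for 3-chlorophenyl

This account rests on a few compounds, and the source may have more. Where it says the series, first, only, none or still open, it means among the compounds named here.

In a functional assay on P388D1 cells (Homo sapiens) for antiproliferative activity, read by sulforhodamine B assay, with a stated time of 48 h (a lower number here means a stronger inhibitor, a higher number a weaker inhibitor), compound 1 (`O=C1NCCN1c1ccc(S(=O)(=O)Nc2cccc(Br)c2)cc1`) gives 90 nM and compound 2 (`Cc1cc(C)cc(NS(=O)(=O)c2ccc(N3CCNC3=O)cc2)c1`) gives 210 nM as the higher, weaker number of the two. Compound 3 (`O=C1NCCN1c1ccc(S(=O)(=O)Nc2cccc(Cl)c2)cc1`) is still unmeasured and carries 3-chlorophenyl in place of 3,5-dimethylphenyl on a sulfonamide nitrogen. Among the measured compounds shown here, the only measured step (a 2.3-fold higher number from compound 1 to compound 2 (0.37 log units; beyond the scatter)) brought in the 3,5-dimethylphenyl group and was modest. Removing that group should therefore reverse a similar amount, so the expected change in this assay is modest and points to a lower number (a 2.1-fold lower number from compound 2 to compound 3 (0.32 log units; beyond the scatter)). For compound 3 the estimated value is 100 nM (range 40 nM to 250 nM).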

Compound 3, half-maximal inhibitory concentration: 78 nM
For compound 3 the middle estimate is 1.3-fold (0.11 log units) above the measured one, within the range that was stated.
By their numbers in this assay, from the lowest: compounds 3 and 1 (each within the scatter of the next); then compound 2.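

In this assay 3-chlorophenyl on the sulfonamide nitrogen gives a lower number than 3,5-dimethylphenyl (a 2.7-fold lower number from compound 2 to compound 3 (0.43 log units; beyond the scatter)), so a second halogen-bearing ring now stands apart from the dimethyl compound. Chloro in place of bromo on an aromatic carbon makes no real difference (a 1.2-fold lower number from compound 1 to compound 3 (0.06 log units; within the scatter)), so this assay does not separate these two halogens. Nothing available explains these results.

Still open, going by these compounds, is how a fluoro group would compare with chloro and bromo. A phenyl ring carrying an amine or a carboxylic acid on the sulfonamide nitrogen also remains untested among these compounds.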